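The compounds below may be only part of what the source reports. "The series", "measured", "known", "first", "only" and "open" are said of these compounds alone.

Compound 2 `CC(C)[C@H](NC(=O)COc1cccc2ccccc12)C(=O)N[C@@H](CC(=O)O)C(=O)COn1nnc2ccccc21` was tested in a functional assay on Jurkat cells (Homo sapiens) for inhibition; a higher number here means a weaker inhibitor, a lower number a stronger inhibitor. In this assay compound 2 gives > 200000 nM, which is a limit of the assay rather than a number. Going by the values given here, compound 1 `COC(=O)c1cc(OCC(=O)[C@H](CC(=O)O)NC(=O)[C@@H](NC(=O)COc2cccc3ccccc23)C(C)C)no1` gives 71000 nM in this assay, and the only measured step, an at least 2.8-fold higher number from compound 1 to compound 2 (0.44 log units; beyond the scatter), ends at the limit of > 200000 nM in this assay, at which 1 of the 2 values shown sits. Compound 3 `CC(C)[C@H](NC(=O)COc1cccc2ccccc12)C(=O)N[C@@H](CC(=O)O)C(=O)COc1ncnc2ccccc12` is not yet measured in this assay. It differs from compound 2 in one place: a group of 10 heavy atoms (8 carbon, 2 nitrogen; one six-membered aromatic ring of carbon only, one six-membered aromatic ring with 2 hetero atoms) in place of a group of 9 heavy atoms (6 carbon, 3 nitrogen; one five-membered aromatic ring with 3 hetero atoms, one six-membered aromatic ring of carbon only), on an oxygen on a saturated carbon. Among the compounds with values here, no measured step exchanges these two groups, so the direction is open, and compound 3 is expected to stay near the limit. Compound 3 is expected to give about 150000 nM in this assay, between 40000 nM and 400000 nM. This expectation amounts to a step of an at least 1.3-fold lower number from compound 2 to compound 3 (0.12 log units; that floor lies within the scatter).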

Compound 3, half-maximal inhibitory concentration: > 200000 nM
Compound 3: only a limit was reported; the forecaster's own chance of this, stated with the estimate: 55%; middle value at least 1.3-fold (0.12 log units) away from the limit.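

Quinazolin-4-yl in place of 5-(methoxycarbonyl)-1,2-oxazol-3-yl gives an at least 2.8-fold higher number from compound 1 to compound 3 (0.44 log units; beyond the scatter), so a second group carrying a six-membered aromatic ring of carbon only also falls short of compound 1 in this assay. Compound 2 and compound 3 both sit at a limit of the assay, and the step between them cannot be read. Among the groups shown on this oxygen, only compound 1 gives a number rather than a limit: the limit of > 200000 nM in this assay, at which 2 of the 3 values shown sit.

On these data alone, it remains open whether a carboxylic acid in place of the methoxycarbonyl on the 1,2-oxazol-3-yl group would keep that number. As far as these compounds go, how a plain phenyl on this oxygen would read in this assay is also open.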